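A few compounds are considered here, and "the series" means these few. Any claim that something is new, unique, unknown or untested is made for them only; others in the source may bear on it.

In a functional assay on MDA-MB-231 cells (Homo sapiens) for antiproliferative activity, with a stated time of 5 days (on this read-out higher numbers stand for weaker inhibition and lower numbers for stronger inhibition), compound 1 `COc1ccc(-n2nc(-c3ccc4ccccc4c3)nc2N2C(=O)COC23C=CC(=O)C=C3)cc1` gives 60 nM. Within the data shown here, compound 2 `O=C1C=CC2(C=C1)OCC(=O)N2c1nc(-c2ccc3ncccc3c2)nn1-c1ccccc1` gives 50 nM, the lowest number so far but within the scatter of compound 1. Compound 3 `O=C1C=CC2(C=C1)OCC(=O)N2c1nc(-c2ccc3ccccc3c2Br)nn1-c1ccccc1` carries 1-bromonaphthalen-2-yl in place of quinolin-6-yl on an aromatic carbon. Among the measured compounds shown here, no measured pair isolates this change, so the expectation rests on these two values alone and remains loose. A moderate step towards weaker inhibition is expected in this assay, estimated as a 3.0-fold higher number from compound 2 to compound 3 (0.48 log units; beyond the scatter). For compound 3 the estimated value is 150 nM, with an expected range of 50 nM to 500 nM.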

Compound 3, half-maximal inhibitory concentration: 50 nM
The estimate for compound 3 lay 3.0-fold (0.48 log units) above the measured number; the measured number falls inside the stated range.
By their numbers in this assay, from the lowest: compounds 2, 3 and 1 (each within the scatter of the next).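

On the aromatic carbon of the five-membered aromatic ring with 3 nitrogen, in this assay, 1-bromonaphthalen-2-yl in place of quinolin-6-yl gives no change at the digits printed from compound 2 to compound 3 (within the scatter). The ring nitrogen and its hydrogen-bond acceptor leave and a bromine enters, yet the read-out stays level, so this acceptor is not needed at this position for a number of this size. No measured evidence bears on why the step is flat. Open: how an amine or a carboxylic acid at this carbon would read, and what the bromine contributes apart from the carbon rings.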